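A few compounds are considered here, and "the series" means these few. Any claim that something is new, unique, unknown or untested is made for them only; others in the source may bear on it.

In a functional assay on A-375 cells (Homo sapiens) for activation, with a stated time of 3 days (on this read-out lower numbers stand for an effect already at smaller amounts and higher numbers for an effect only at larger amounts of compound), compound 1 (`O=C(Nc1ccc(-c2cscn2)cc1)C1CCCN(C(=O)c2ccc(F)c(F)c2)C1`) reads > 20000 nM, which is a limit of the assay. Compound 2 (`O=C(Nc1ccc(-c2cscn2)cc1)C1CCCN(Cc2ccccc2F)C1`) gives 7000 nM. Compound 3 (`O=C(Nc1ccc(-c2cscn2)cc1)C1CCCN(Cc2cccc(F)c2)C1`) gives 5000 nM, and the values of these two benzyl compounds lie within the scatter of each other.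

Compound 4 (`O=C(Nc1ccc(-c2cscn2)cc1)C1CCCN(Cc2ccc(F)cc2)C1`) has 4-fluorophenyl in place of the 3-fluorophenyl of compound 3, on a saturated chain carbon bound to an amine nitrogen in a ring: 4-fluorophenyl in place of 3-fluorophenyl on a saturated chain carbon bound to an amine nitrogen in a ring.

The closest measured change, 3-fluorophenyl in place of 2-fluorophenyl at that same place, is a 1.4-fold lower number from compound 2 to compound 3 (0.15 log units; within the scatter). The other two steps, an at least 2.8-fold lower number from compound 1 to compound 2 (0.45 log units; beyond the scatter) and an at least 4.0-fold lower number from compound 1 to compound 3 (0.60 log units; beyond the scatter), replace the (3,4-difluorophenyl)carbonyl group, so they bear only on having a benzyl group there at all.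

No step beyond the scatter is therefore expected in this assay. The estimated step is a 1.2-fold higher number from compound 3 to compound 4 (0.08 log units; within the scatter). For compound 4 the expected value is 6000 nM. The estimated range for compound 4 runs from 2200 nM to 15000 nM.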

Compound 4, half-maximal effective concentration: 5000 nM
Compound 4: the middle estimate sits 1.2-fold (0.08 log units) above what was measured; low and high end bracket the measured number.
By their numbers in this assay, from the lowest: compounds 3, 4 and 2 (each within the scatter of the next). At a limit, above all of these: compound 1.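

The 4-fluorophenyl group reads like the other two fluorophenyl groups at this place: there is no change at the digits printed from compound 3 to compound 4 (within the scatter), and there is a 1.4-fold lower number from compound 2 to compound 4 (0.15 log units; within the scatter), so the compounds shown do not separate the three fluorine placements. The 4-fluorobenzyl group also shares the advantage of the other benzyl compounds over the (3,4-difluorophenyl)carbonyl group, with an at least 4.0-fold lower number from compound 1 to compound 4 (0.60 log units; beyond the scatter). In this assay compound 1 stands at a limit rather than a number, so this step gives only a bound: the limit of > 20000 nM in this assay, at which 1 of the 4 values shown sits.

On these data alone, it remains open whether a benzyl group with no fluorine, or one carrying a methoxy group, a nitrile or a carboxylic acid instead, would read differently. Also open, as far as these compounds go, is whether any such group would move the number beyond the scatter of these three benzyl compounds.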